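Adding a second chloro to compound 2

The source may report more compounds than this note shows. Statements on the series, on what has been measured and on what is new or still open speak of the compounds shown alone.

- compound 1 `NC(=O)c1c(NC(=O)c2ccccc2Cl)sc2c1CCN(Cc1ccccc1)C2`: 38400 nM
- compound 2 `NC(=O)c1c(NC(=O)c2ccccc2Cl)sc2c1CCN(Cc1ccccc1Cl)C2`: 27500 nM
- compound 3 `NC(=O)c1c(NC(=O)c2ccccc2Cl)sc2c1CCN(Cc1ccc(Cl)cc1Cl)C2`: not yet measured

Among the compounds with values here, only two numbers are available in a functional assay on HeLa cells (Homo sapiens) for antiproliferative activity, with a stated time of 24 h (a lower number here means a stronger inhibitor, a higher number a weaker inhibitor), and compound 2, at 27500 nM, lies within the scatter of compound 1. Compound 3 differs from compound 2 by one change: chloro in place of hydrogen on an aromatic carbon. This places chloro in place of hydrogen on an aromatic carbon, turning 2-chlorobenzyl to 2,4-dichlorobenzyl. Within the data shown here, the only measured step of this kind is a 1.4-fold lower number from compound 1 to compound 2 (0.14 log units; within the scatter), and it introduced its chloro at a different place. Among the measured compounds shown here, that single small step is the only guide, so a small shift toward a lower number in this assay is expected, with nothing clearly beyond the scatter. The expected change is a 1.3-fold lower number from compound 2 to compound 3 (0.10 log units; within the scatter). Compound 3 is therefore estimated at 22000 nM, with an expected range from 12000 nM to 38000 nM.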

Compound 3, half-maximal inhibitory concentration: 21100 nM
The estimate for compound 3 lay 1.0-fold (0.02 log units) above the measured number; the range from low to high includes it.
By their numbers in this assay, from the lowest: compounds 3, 2 and 1 (each within the scatter of the next).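

Placing a chloro on the aromatic carbon meta to a chloro group and para to a large group, the change from 2-chlorobenzyl to 2,4-dichlorobenzyl, stays within the scatter in this assay (a 1.3-fold lower number from compound 2 to compound 3 (0.12 log units; within the scatter)). Within the data shown here, this position therefore behaves like the one changed earlier, with no step yet beyond the scatter. Even with both chloro groups counted together, the comparison with the unsubstituted benzyl compound stays within the scatter (a 1.8-fold lower number from compound 1 to compound 3 (0.26 log units; within the scatter)), and no measurement available here bears on this result.

As far as these compounds go, it remains open whether a methoxy group, an amine or a carboxylic acid at this same position would give a step beyond the scatter. Also open, from the compounds shown here alone, is what a longer chain in place of the benzyl group would do in this assay.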